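The source may hold more compounds than are shown below. What is called first, only, known or untested is meant among the compounds shown, and "the series" means these compounds.

Working notes on the series. Compound 1 `O=C(CSc1nc(Nc2ccccc2)c2ccccc2n1)Nc1ccc(Br)cc1` gives 19300 nM in a functional assay on MGC-803 cells (Homo sapiens) for inhibition, read by MTT assay, with a stated time of 72 h; on this read-out lower numbers stand for stronger inhibition and higher numbers for weaker inhibition. For the measured compounds named here, compound 2 `O=C(CSc1nc(Nc2ccccc2)c2ccccc2n1)Nc1ccc(Cl)cc1Cl` gives 12300 nM, and the change a 1.6-fold lower number from compound 1 to compound 2 (0.20 log units; within the scatter) is the only measured step in this set. Compound 3 `C=CC(=O)Nc1cccc(NC(=O)CSc2nc(Nc3ccccc3Br)c3ccccc3n2)c1` gives 12800 nM, the second highest of the three numbers; its gap to compound 2 and to compound 1 lies within the scatter, so no order among the three can be read. Compound 4 `C=CC(=O)Nc1cccc(NC(=O)CSc2nc(Nc3cc(OC)c(OC)c(OC)c3)c3ccccc3n2)c1` differs from compound 3 by 3,4,5-trimethoxyphenyl in place of 2-bromophenyl on a nitrogen on an aromatic ring. Going by the values given here, no measured step touches the nitrogen on the aromatic ring, and the one step measured, at the amide-type nitrogen, stayed within the scatter. The step of a 1.3-fold lower number from compound 3 to compound 4 (0.11 log units; within the scatter) is therefore expected to be small. Compound 4 is estimated at 10000 nM, within 3500 nM to 30000 nM.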

Compound 4, half-maximal inhibitory concentration: > 50000 nM
Compound 4: only a limit was reported; the forecaster's own chance of this, stated with the estimate: 5%; at least 5.0-fold (0.69 log units) between middle value and limit.
By their numbers in this assay, from the lowest: compounds 2, 3 and 1 (each within the scatter of the next). At a limit, above all of these: compound 4.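

In this assay, the nitrogen on the aromatic ring responds to its aryl group: 3,4,5-trimethoxyphenyl in place of 2-bromophenyl gives an at least 3.9-fold higher number from compound 3 to compound 4 (0.59 log units; beyond the scatter). For the compounds shown here, this is the first step beyond the scatter, as the earlier step at the amide-type nitrogen stayed within it. The figure for compound 4 is a limit, not a number: the limit of > 50000 nM in this assay, at which 1 of the 4 values shown sits.

No compound shown separates the departure of bromine from the arrival of the methoxy groups. From the compounds shown here alone, whether a single methoxy group, an amine or a carboxylic acid on this aryl ring would be tolerated stays open.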